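The source may report more compounds than this note shows. Statements on the series, on what has been measured and on what is new or still open speak of the compounds shown alone.

Compound 1 `O=c1cc(CSc2nc3ccccc3s2)oc2ccccc12` gives in a functional assay on HEp-2 cells (Homo sapiens) for cytotoxicity, read by MTT assay, with a stated time of 72 h (on this read-out lower numbers stand for stronger inhibition and higher numbers for weaker inhibition), only a limit of the assay, > 25000 nM. Compound 2 `Cc1cc(C)nc(SCc2cc(=O)c3cc(Cl)ccc3o2)n1` likewise gives in this assay only a limit, > 25000 nM. Both readings sit at the limit of > 25000 nM in this assay, at which 2 of the 2 values shown sit, so compound 1 stands on a limit and not on a number. Compound 3 `O=c1cc(CSc2nc3ccccc3s2)oc2ccc(Cl)cc12` differs from compound 1 by chloro in place of hydrogen on an aromatic carbon, meta to a fused ring and para to a fused ring. For the measured compounds named here, no measured step exists between the two. In this assay no step beyond the usual scatter is expected, a step that the limit leaves unreadable from compound 1 to compound 3. Compound 3 is expected near 30000 nM, within 8000 nM to 100000 nM, most probably reported as a limit again.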

Compound 3, half-maximal inhibitory concentration: > 25000 nM
Compound 3: a limit, no number (the forecaster's own chance of this, stated with the estimate: 80%); the middle value is on the limit's open side.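

No step can be read from compound 1 to compound 3, since with chloro in place of hydrogen on an aromatic carbon both still stand on a limit: the limit of > 25000 nM in this assay, at which 3 of the 3 values shown sit. The compounds shown leave open what chloro does to cytotoxicity in this assay, as none of them gives a number.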